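This account rests on a few compounds, and the source may have more. Where it says the series, first, only, none or still open, it means among the compounds named here.

Working notes on the series. For the measured compounds named here, compound 1 `Cc1cc(N2CCCC2)cn2c(CSCCc3ccccc3)cnc12` and compound 2 `Cc1cc(-n2cccc2)cn2c(CSCc3ccccc3)cnc12` are the two members measured so far. In an ADME assay on HEL cells (Homo sapiens) for cytotoxicity, with a stated time of 3 days (on this read-out lower numbers stand for higher toxicity in this test and higher numbers for lower toxicity in this test), compound 1 gives 20 ug/mL, and in this assay compound 2 gives 20 ug/mL; compound 1 therefore stands level with compound 2, the two values lying within the scatter of each other. Compound 3 `Cc1cc(Sc2ccc(O)cc2)cn2c(CSCCc3ccccc3)cnc12` is the next member, not yet measured in this assay. Against compound 1 it differs in one place: (4-hydroxyphenyl)sulfanyl in place of pyrrolidin-1-yl on an aromatic carbon. Going by the values given here, with no measured step of this kind available, the step of no change at the digits printed from compound 1 to compound 3 (within the scatter) is expected to stay within the scatter, in no particular direction. Compound 3 is estimated at 20 ug/mL in this assay, with a range from 7 ug/mL to 60 ug/mL.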

Compound 3, minimum cytotoxic concentration: 4 ug/mL
Compound 3: the middle estimate sits 5.0-fold (0.70 log units) above what was measured; measured number outside the range, below it.
By their numbers in this assay, from the lowest: compound 3; then compounds 1 and 2 (each within the scatter of the next).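

At the aromatic carbon meta to a methyl group, the substituent matters in this assay: (4-hydroxyphenyl)sulfanyl in place of pyrrolidin-1-yl gives a 5.0-fold lower number from compound 1 to compound 3 (0.70 log units; beyond the scatter), which means higher toxicity in this test. For the compounds shown here, compounds 1 and 2 differ in more than one place, so they gave no single-change step at this position. Nothing available accounts for this step.

From the compounds shown here alone, it remains open whether the sulfur link, the phenyl ring or the hydroxyl carries the step. Phenylsulfanyl without the hydroxyl, or 4-hydroxyphenyl bonded directly to the ring carbon, would separate these parts.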